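Exchanging the aryl on the ring nitrogen of compound 3

The source may report more compounds than this note shows. Statements on the series, on what has been measured and on what is new or still open speak of the compounds shown alone.

Measured so far:
compound 1 `COc1cc(/C=C/C(C)=O)ccc1OCc1cn(-c2c(F)cccc2F)nn1` — 24200 nM
compound 2 `COc1ccc(-n2cc(COc3ccc(/C=C/C(C)=O)cc3OC)nn2)cc1` — 2010 nM
compound 3 `COc1cc(/C=C/C(C)=O)ccc1OCc1cn(-c2c(Cl)cccc2Cl)nn1` — 3070 nM

All three were tested in a functional assay on PC-3 cells (Homo sapiens) for antiproliferative activity, read by MTT assay, with a stated time of 48 h; on this read-out higher numbers stand for weaker inhibition and lower numbers for stronger inhibition. Compound 3 stands second highest of the three numbers: the step of a 1.5-fold higher number from compound 2 to compound 3 (0.18 log units; within the scatter) lies within the scatter, whereas a 7.9-fold lower number from compound 1 to compound 3 (0.90 log units; beyond the scatter) lies beyond it. Compound 4 `COc1cccc(-n2cc(COc3ccc(/C=C/C(C)=O)cc3OC)nn2)c1` has not been measured. It differs from compound 3 in one place: 3-methoxyphenyl in place of 2,6-dichlorophenyl on an aromatic nitrogen. Going by the values given here, no measured step replaces 2,6-dichlorophenyl by 3-methoxyphenyl, and no measured compound carries a 3-methoxyphenyl. The step that bears on it most is a 12-fold lower number from compound 1 to compound 2 (1.08 log units; beyond the scatter), which brings a methoxyphenyl onto the same nitrogen, and a 1.5-fold higher number from compound 2 to compound 3 (0.18 log units; within the scatter) shows the 4-methoxyphenyl and the 2,6-dichlorophenyl giving numbers within the scatter of each other. The step of a 1.2-fold lower number from compound 3 to compound 4 (0.09 log units; within the scatter) is therefore expected to stay within the scatter. The estimate for compound 4 is 2500 nM, with a range from 800 nM to 8000 nM.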

Compound 4, half-maximal inhibitory concentration: 31600 nM
The estimate for compound 4 lay 13-fold (1.10 log units) below the measured number; the measured number lies above the stated range.
By their numbers in this assay, from the lowest: compounds 2 and 3 (each within the scatter of the next); then compounds 1 and 4 (each within the scatter of the next).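

In this assay, 3-methoxyphenyl in place of 4-methoxyphenyl on the aromatic nitrogen gives a 16-fold higher number from compound 2 to compound 4 (1.20 log units; beyond the scatter), so a methoxyphenyl at this position does not by itself secure the low number of compound 2, and which methoxyphenyl is present matters. 3-methoxyphenyl in place of 2,6-dichlorophenyl gives a 10-fold higher number from compound 3 to compound 4 (1.01 log units; beyond the scatter), whereas in place of 2,6-difluorophenyl it gives a 1.3-fold higher number from compound 1 to compound 4 (0.12 log units; within the scatter). The four aryl groups thus form two pairs, 4-methoxyphenyl with 2,6-dichlorophenyl and 3-methoxyphenyl with 2,6-difluorophenyl, so each pair mixes a methoxyphenyl with a 2,6-dihalophenyl.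

Nothing available here accounts for this split. Going by these compounds, it also remains open how a plain phenyl, a benzyl group or a 3-hydroxyphenyl on the same nitrogen would compare with these four.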